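The compounds below may be only part of what the source reports. "The series", "measured", "known", "first", "only" and "open" are said of these compounds alone.

Compound 1 `O=C(/C=C/c1ccc(OCc2cn(Cc3ccc(Br)cc3)nn2)cc1)c1ccc([N+](=O)[O-])cc1` gives 21% in a functional assay on HepG2 cells (Homo sapiens) for inhibition, read by MTT assay, with a stated time of 48 h, tested at 10 uM; a lower number here means less inhibition of growth, a higher number more inhibition of growth at the concentration tested.
Compound 2 `O=C(/C=C/c1ccc(OCc2cn(Cc3ccccc3F)nn2)cc1)c1ccc([N+](=O)[O-])cc1` gives 22%.
Compound 3 `O=C(/C=C/c1ccc(OCc2cn(Cc3cccc(F)c3)nn2)cc1)c1ccc([N+](=O)[O-])cc1` gives 43%.

Compound 3 stands highest of the three numbers. Its margin over the nearest, compound 2, is a number 21 percentage points higher from compound 2 to compound 3 (beyond the scatter), and over the furthest, compound 1, it is a number 22 percentage points higher from compound 1 to compound 3 (beyond the scatter); both lie beyond the scatter. By contrast, the step of a number 1 percentage points higher from compound 1 to compound 2 (within the scatter) stays within the scatter, so compound 1 and compound 2 cannot be ordered.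

Compound 4 `O=C(/C=C/c1ccc(OCc2cn(Cc3ccc(F)cc3)nn2)cc1)c1ccc([N+](=O)[O-])cc1` differs from compound 3 in one place: 4-fluorophenyl in place of 3-fluorophenyl on a saturated chain carbon bound to an aromatic nitrogen. Among the compounds with values here, the steps that bear on this are the two in which a halogen on that phenyl ring changes its place, a number 21 percentage points higher from compound 2 to compound 3 (beyond the scatter) and a number 22 percentage points higher from compound 1 to compound 3 (beyond the scatter), each of modest size, and both running toward the 3-fluorophenyl of compound 3. Compound 1, whose 4-bromophenyl is the closest relative of the 4-fluorophenyl entering in compound 4, sits low. A modest fall is therefore expected, a number 13 percentage points lower from compound 3 to compound 4 (beyond the scatter), though a number within the scatter of compound 3 cannot be ruled out.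

Compound 4 is estimated at 30%, with a range from 15% to 48%.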

Compound 4, percent growth inhibition at one concentration: 25%
The estimate for compound 4 lay 5 percentage points above the measured number, and the stated range covers the measured number.
By their numbers in this assay, from the lowest: compounds 1, 2 and 4 (each within the scatter of the next); then compound 3.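

Shifting the fluorine on the benzyl ring lowers the reading in this assay, a number 18 percentage points lower from compound 3 to compound 4 (beyond the scatter), so the 4-fluorophenyl does not keep the margin of the 3-fluorophenyl. The 4-fluorophenyl and the 2-fluorophenyl cannot be told apart, a number 3 percentage points higher from compound 2 to compound 4 (within the scatter), which leaves the 3-fluorophenyl as the only one of the three fluorine placements that stands out. Fluoro in place of bromo on an aromatic carbon also gives no readable change, a number 4 percentage points higher from compound 1 to compound 4 (within the scatter), so the 4-bromophenyl and the 4-fluorophenyl cannot be ordered, and the identity of the halogen shows no effect in this pair.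

Nothing available explains why the 3-fluorophenyl stands apart. On these data alone, whether a chloro group, a methoxy group or an amine in place of the fluorine of compound 3 would keep its margin stays open.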